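Dropping the drawn configuration on the chain alcohol

A few compounds are considered here, and "the series" means these few. Any claim that something is new, unique, unknown or untested is made for them only; others in the source may bear on it.

Measured so far:
compound 1: `OC(CCn1nc2c(Br)c(Br)c(Br)c(Br)c2n1)c1ccc(Br)cc1` — 82%
compound 2: `C[C@@H](O)CCn1nc2c(Br)c(Br)c(Br)c(Br)c2n1` — 109%

Of the compounds shown here, two have been tested in a functional assay on MCF7 cells (Homo sapiens) for antiproliferative activity, read by MTT assay, with a stated time of 24 h, tested at 12.5 uM; a higher number here means a weaker effect of the compound at the concentration tested, a lower number a stronger effect. Compound 2 gives 109%, the higher of the two numbers, which here means the weaker effect. Compound 1 gives 82%, a lower number, and the gap between the two lies beyond the usual scatter. These two compounds differ in more than one place, so their difference is not followed here.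

The next compound, compound 3, `CC(O)CCn1nc2c(Br)c(Br)c(Br)c(Br)c2n1`, is to be measured in this assay. It differs from compound 2 only in this: the two compounds have the same atoms and bonds; at least one stereo element is drawn with a configuration in one of them and without one in the other: 1 of 1 stereo elements differ; a stereocentre at a saturated chain carbon is drawn R in compound 2 and without a configuration in compound 3. The atoms and bonds are identical, so the change is in how the one stereocentre is drawn, not in what is attached.

Within the data shown here, with no step between measured compounds available, the expected step is none beyond the scatter, perhaps a slight move downward. Compound 3 is therefore estimated to give 100%, in a range from 82% to 115%. The step this estimate means, a number 9 percentage points lower from compound 2 to compound 3 (within the scatter), is expected to be small.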

Compound 3, a percentage reported as activity, at one concentration (the size of the read-out at that concentration, not a potency): 99%
Beside the measured number, compound 3's estimate is 1 percentage points above it; the range from low to high includes it.
By their numbers in this assay, from the lowest: compound 1; then compounds 3 and 2 (each within the scatter of the next).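

In this assay, going from the drawn configuration to none at this saturated chain carbon gives a number 10 percentage points lower from compound 2 to compound 3 (within the scatter), so this pair offers no sign that the way the stereocentre is drawn matters at the concentration tested. The comparison can speak to only one structural point: the fact that one of compounds 2 and 3 is drawn with a defined configuration and the other without, at the place where they differ

Among these compounds, the substituent on the same carbon tells a different story: methyl in place of 4-bromophenyl gives a number 17 percentage points higher from compound 1 to compound 3 (beyond the scatter), a modest step towards a weaker effect and the first single change here that clears the usual scatter.

Going by these compounds, whether the other drawn configuration at this carbon would read the same remains open. So does the effect of other groups at this place, such as an unsubstituted phenyl ring or an ethyl group, or of an amine in place of the hydroxyl.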